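Removing a hydroxyethyl tail from a sulfonamide on the shared core

This account rests on a few compounds, and the source may have more. Where it says the series, first, only, none or still open, it means among the compounds named here.

Measured compounds:
Compound 1 `CCC1C(=O)N(C)c2cnc(-n3ccc4cc(C(=O)NC)ccc43)nc2N1c1ccn(C)n1`, in a functional assay on Huh-7 cells (Homo sapiens) for antiproliferative activity, read by CCK-8 assay, with a stated time of 72 h (a lower number here means a stronger inhibitor of growth, a higher number a weaker inhibitor of growth), compound 1 gives 13200 nM.
Compound 2 `CCC1C(=O)N(C)c2cnc(Nc3ccc(S(=O)(=O)NCCCO)cc3)nc2N1c1ccn(C)n1`, in this assay compound 2 is reported as "not active" (no number reported), with no single number given.
Compound 3 `CCCCNC(=O)c1ccc2c(ccn2-c2ncc3c(n2)N(C2CCCC2)[C@H](CC)C(=O)N3C)c1`, in this assay compound 3 gives 683 nM.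

Of the compounds shown here, three built on one shared core have been tested so far. Among the compounds with values here, compound 3 is the one with a reported number that points to the stronger growth inhibition, compound 1 sits far weaker, and compound 2 stands apart from both: for it no number exists at all, only the note that it showed no measurable activity in this assay. Compound 2 carries an anilino side with a sulfonamide whose nitrogen bears a 3-hydroxypropyl chain.

Compound 4 `CCC1C(=O)N(C)c2cnc(Nc3ccc(S(=O)(=O)NC)cc3)nc2N1c1ccn(C)n1` keeps everything of compound 2 except that chain. The change is hydrogen in place of 2-hydroxyethyl on a saturated chain carbon bound to a sulfonamide nitrogen. Within the data shown here, since no step between two measured compounds covers this change, the size of the effect in this assay cannot be read off; the expectation is a small shift, most likely none beyond the scatter, with compound 4 remaining a weak inhibitor like compound 2. Compound 4 is therefore estimated at 25000 nM, within a range of 6000 nM to 100000 nM, with a real chance that only a limit is reported.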

Compound 4, concentration for 50% growth inhibition: 11900 nM
For compound 4 the middle estimate is 2.1-fold (0.32 log units) above the measured one, and the stated range covers the measured number.
By their numbers in this assay, from the lowest: compound 3; then compounds 4 and 1 (each within the scatter of the next).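

In this assay, within the data shown here, compound 4 gives 11900 nM while compound 2 is reported only as not active, with no number, so no step between them can be read. No evidence at hand explains this result. From the compounds shown here alone, how much the change from 3-hydroxypropyl to methyl shifts growth inhibition on this core therefore remains open.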